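From cyclohexyl to phenyl on a shared core

The compounds below may be only part of what the source reports. "The series", "measured", "known", "first", "only" and "open" are said of these compounds alone.

For the measured compounds named here, in a functional assay on KBVIN cells (Homo sapiens) for cytotoxicity, read by MTT assay, with a stated time of 72 h (a lower number here means that less compound is needed, a higher number that more compound is needed for the effect), compound 2 (`COc1ccc(Nc2cc(C3CCCCC3)oc(=O)c2)cc1`) gives 4.39 uM and stands highest of the three numbers so far. Compound 1 (`COc1cccc(Nc2cc(-c3ccccc3)oc(=O)c2)c1`) gives 0.55 uM and compound 3 (`COc1ccc(Nc2cc(-c3ccc4ccccc4c3)oc(=O)c2)cc1`) gives 0.13 uM in the same test, both lower than compound 2 by more than the scatter. Compound 4 (`COc1ccc(Nc2cc(-c3ccccc3)oc(=O)c2)cc1`) departs from compound 2 by a single change (phenyl in place of cyclohexyl on an aromatic carbon): phenyl in place of cyclohexyl on an aromatic carbon. Going by the values given here, no measured pair isolates this change. Compound 1 also bears phenyl, and its value of 0.55 uM lies well under that of compound 2, so a clear fall in this assay is expected, beyond the scatter. The expected move is a 9.8-fold lower number from compound 2 to compound 4 (0.99 log units; beyond the scatter) in size. Compound 4 is estimated at 0.45 uM with an expected range from 0.15 uM to 1.5 uM in this measurement.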

Compound 4, concentration for half-maximal effect: 0.098 uM
Compound 4: the middle estimate sits 4.6-fold (0.66 log units) above what was measured; the measured number lies below the stated range.
By their numbers in this assay, from the lowest: compounds 4 and 3 (each within the scatter of the next); then compound 1; then compound 2.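

For the compounds shown here, on the aromatic carbon next to the ring oxygen, replacing cyclohexyl with phenyl gives, in this assay, a 45-fold lower number from compound 2 to compound 4 (1.65 log units; beyond the scatter) as the first step that isolates this position. The two groups have the same count of heavy atoms, and the computed comparison separates them as a non-aromatic and an aromatic six-membered carbon ring. Nothing available explains why this change has so large an effect. As far as these compounds go, whether a pyridyl ring, an amine or a longer alkyl chain on this carbon would keep the number as low as phenyl does remains open.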